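Working notes: sec-butyl to isopropyl

This account rests on a few compounds, and the source may have more. Where it says the series, first, only, none or still open, it means among the compounds named here.

Compound 1 `CCCCCC(C#CC(=O)OC)O/C=C/C(=O)OC`: 1900 nM
Compound 2 `COC(=O)C#CC(O/C=C/C(=O)OC)C1CCCCC1`: 2500 nM
Compound 3 `CCC(C)C(C#CC(=O)OC)O/C=C/C(=O)OC`: 340 nM

In a functional assay on HBL-100 cells (Homo sapiens) for antiproliferative activity, read by sulforhodamine B assay, with a stated time of 48 h (a higher number here means a weaker inhibitor of growth, a lower number a stronger inhibitor of growth), compound 3 has the lowest number of the three. Compound 4 `COC(=O)C#CC(O/C=C/C(=O)OC)C(C)C` differs from it by hydrogen in place of methyl on a saturated chain carbon, three bonds along the chain from an oxygen on an unsaturated carbon and a triple-bonded carbon, which reads as sec-butyl to isopropyl. Within the data shown here, no measured step makes this change alone. The nearest evidence is replacement of the whole group: a 5.6-fold lower number from compound 1 to compound 3 (0.75 log units; beyond the scatter) and a 7.4-fold lower number from compound 2 to compound 3 (0.87 log units; beyond the scatter), both beyond the scatter, whereas a 1.3-fold higher number from compound 1 to compound 2 (0.12 log units; within the scatter) stays within it. These steps show no simple trend, so the direction is uncertain. A modest step towards a higher number is expected, with compound 3 at the low end at 340 nM. The estimated change is a 1.9-fold higher number from compound 3 to compound 4 (0.28 log units; within the scatter). Compound 4 is expected at 650 nM, with a range of 220 nM to 1900 nM.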

Compound 4, concentration for 50% growth inhibition: 450 nM
Estimate against measurement, compound 4: 1.4-fold (0.16 log units) above, within the range that was stated.
By their numbers in this assay, from the lowest: compounds 3 and 4 (each within the scatter of the next); then compounds 1 and 2 (each within the scatter of the next).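

In this assay, the step that removes only the methyl, a 1.3-fold higher number from compound 3 to compound 4 (0.12 log units; within the scatter), stays within the scatter, so sec-butyl and isopropyl are not told apart at this position. Isopropyl also stands clear of the two other groups, with a 5.6-fold lower number from compound 2 to compound 4 (0.74 log units; beyond the scatter) and a 4.2-fold lower number from compound 1 to compound 4 (0.63 log units; beyond the scatter), so the lower numbers do not depend on that methyl alone. No evidence on the cause accompanies this result.

On these data alone, whether a tert-butyl or a cyclopropyl group at this carbon would hold these lower numbers remains open. So does the effect of an amine on the chain.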